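A few compounds are considered here, and "the series" means these few. Any claim that something is new, unique, unknown or untested is made for them only; others in the source may bear on it.

Going by the values given here, compound 3 `CC(C)(C)c1ccc(OC(C)(C)C2OCC(C/C=C\CCC(=O)O)C(c3cccnc3)O2)cc1` gives 280 nM in an assay for inhibition of Thromboxane-A synthase (Homo sapiens), using microsomes (a lower number here means a stronger inhibitor, a higher number a weaker inhibitor), the highest of the three numbers so far; compound 1 `Cc1ccc(C#N)c(OC(C)(C)C2OCC(C/C=C\CCC(=O)O)C(c3cccnc3)O2)c1` gives 50 nM and compound 2 `COc1ccc(OC(C)(C)C2OCC(C/C=C\CCC(=O)O)C(c3cccnc3)O2)cc1` gives 41 nM. Compound 4 `CC(C)(Oc1ccc(F)cc1)C1OCC(C/C=C\CCC(=O)O)C(c2cccnc2)O1` differs from compound 3 by fluoro in place of tert-butyl on an aromatic carbon. Among the compounds with values here, the steps that bear on this change are a 5.6-fold higher number from compound 1 to compound 3 (0.75 log units; beyond the scatter) and a 6.8-fold higher number from compound 2 to compound 3 (0.83 log units; beyond the scatter), each an exchange of the aryl group on the same oxygen and each beyond the scatter. Within the data shown here, no fluoro analogue has yet been measured in this assay. Since the change removes the tert-butyl that sets compound 3 apart from compounds 1 and 2, a move back toward their numbers is expected, though its exact extent is uncertain. Compound 4 is estimated at 60 nM (range 25 nM to 150 nM), corresponding to an expected 4.7-fold lower number from compound 3 to compound 4 (0.67 log units; beyond the scatter).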

Compound 4, half-maximal inhibitory concentration: 51 nM
The estimate for compound 4 lay 1.2-fold (0.07 log units) above the measured number, within the range that was stated.
By their numbers in this assay, from the lowest: compounds 2, 1 and 4 (each within the scatter of the next); then compound 3.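

In this assay, fluoro in place of tert-butyl gives a 5.5-fold lower number from compound 3 to compound 4 (0.74 log units; beyond the scatter) and places the new aryl group level with the other two, with a 1.2-fold higher number from compound 2 to compound 4 (0.09 log units; within the scatter) and a 1.0-fold higher number from compound 1 to compound 4 (0.01 log units; within the scatter) as the steps. Of the four aryl groups on this oxygen, only 4-(tert-butyl)phenyl stands apart, while 4-fluorophenyl, 4-methoxyphenyl and 2-cyano-5-methylphenyl cannot be told apart in this read-out. No measured evidence accounts for this result. Open, from the compounds shown here alone, is whether an isopropyl, trifluoromethyl or amino group in place of fluoro would stay with compound 4 or move toward compound 3.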